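This account rests on a few compounds, and the source may have more. Where it says the series, first, only, none or still open, it means among the compounds named here.

Of the compounds shown here, three built on one shared core have been tested in an assay on isolated protein (Cavia porcellus) with Sigma non-opioid intracellular receptor 1 (Homo sapiens) as the target, read by radioligand binding; a higher number here means a weaker inhibitor, a lower number a stronger inhibitor. Compound 1 `O=c1cc(-c2ccccc2)oc2cccc(OCCCN3CCC(O)CC3)c12` gives 125 nM in this assay; compound 2 `O=c1cc(-c2ccccc2)oc2cccc(OCCCCCCCN3CCC(O)CC3)c12` gives 36 nM; compound 3 `CN(C)CCCCCCOc1ccc2oc(-c3ccccc3)cc(=O)c2c1` gives 432 nM. Among these three numbers compound 3 stands highest, meaning it is the weakest inhibitor of the set. Its nearest neighbour is compound 1, whose number lies below it by more than the usual scatter, and compound 2 lies further still below it. Compound 3 carries an open chain ending in a basic nitrogen, attached through an oxygen to the core, whereas compounds 1 and 2 carry their basic nitrogen inside a ring on chains of different length.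

Compound 4 `CN(C)CCCCCCCCCCOc1ccc2oc(-c3ccccc3)cc(=O)c2c1` differs from compound 3 in one place: 4-(dimethylamino)butyl in place of dimethylamino on a saturated chain carbon, six bonds along the chain from an oxygen on an aromatic ring. In effect the basic nitrogen sits further out along the chain from the oxygen. Within the data shown here, no measured pair here shows exactly this step. Among the measured compounds shown here, the only related comparison is that compound 1, with the shorter chain, gives 125 nM while compound 2, with the longer chain, gives 36 nM. On that basis the number for compound 4 is expected to fall by a moderate step of a 2.9-fold lower number from compound 3 to compound 4 (0.46 log units; beyond the scatter), likely beyond the scatter. The estimate for compound 4 is 150 nM, with a range from 50 nM to 500 nM.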

Compound 4, half-maximal inhibitory concentration: 297 nM
The estimate for compound 4 lay 2.0-fold (0.30 log units) below the measured number, and the stated range covers the measured number.
By their numbers in this assay, from the lowest: compound 2; then compound 1; then compounds 4 and 3 (each within the scatter of the next).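

In this assay, putting 4-(dimethylamino)butyl in place of dimethylamino on a saturated chain carbon, six bonds along the chain from an oxygen on an aromatic ring, gives a 1.5-fold lower number from compound 3 to compound 4 (0.16 log units; within the scatter), so the two compounds cannot be told apart. Among these compounds, this is the first direct reading of this change, and it shows that moving the dimethylamino group further out along an already long chain, with the rest of the molecule unchanged, has no effect that can be separated from the ordinary spread of repeat measurements. No measurement at hand offers an explanation for this result.

As far as these compounds go, compounds 1 and 2 differ from compounds 3 and 4 in more than one place, so the gap between their values says nothing firm about this chain, and whether a lengthening has a clearer effect on a shorter chain at this position remains open. Also unsettled is what a shorter chain ending in dimethylamino would give, or a chain of the same length as in compound 4 ending in a primary amine or a carboxylic acid.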